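Swapping fluoro for chloro on the pyridine ring of compound 2

The source may hold more compounds than are shown below. What is called first, only, known or untested is meant among the compounds shown, and "the series" means these compounds.

Measured compounds:
- compound 1, `COc1cccc(S(=O)(=O)/C=C/c2ccccn2)c1`: 74%
- compound 2, `COc1cccc(S(=O)(=O)/C=C/c2ncccc2F)c1`: 31%

In an ADME assay on microsomes from liver (Homo sapiens) for metabolic stability, read by LC-MS, using NADPH, with stated times of 5 min and 30 min, tested at 1 uM (on this read-out lower numbers stand for a less stable compound and higher numbers for a more stable compound), compound 1 gives 74%, while compound 2 gives 31%. Compound 2 stands lowest of the two numbers shown; the only step among the measured compounds, a number 43 percentage points lower from compound 1 to compound 2 (beyond the scatter), is a large one and lies beyond the scatter.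

Compound 3, `COc1cccc(S(=O)(=O)/C=C/c2ncccc2Cl)c1`, is not yet measured. It differs from compound 2 by chloro in place of fluoro on an aromatic carbon, sitting on an aromatic carbon of a six-membered aromatic ring with one nitrogen, ortho to a large group and two atoms from the ring nitrogen.

Within the data shown here, no measured step exchanges one halogen for another; the single step available replaces hydrogen by fluoro, and it is large and downward. That step does not directly tell what chloro in place of fluoro will do, so the expectation for compound 3 rests mainly on compound 2 itself, with wide uncertainty. Compound 3 is expected to give 28%, within a range of 10% to 55%, so that the estimated step of a number 3 percentage points lower from compound 2 to compound 3 (within the scatter) stays near the scatter.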

Compound 3, percent of the compound remaining: 22%
Compound 3: middle estimate off by 6 percentage points, on the high side; the measured number falls inside the stated range.
By their numbers in this assay, from the lowest: compounds 3 and 2 (each within the scatter of the next); then compound 1.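

In this assay the exchange of one halogen for the other gives a number 9 percentage points lower from compound 2 to compound 3 (within the scatter) and so does not separate fluoro from chloro at this position. The earlier compounds showed a large fall with fluoro alone, and chloro in place of hydrogen on the same aromatic carbon now gives a second large step, a number 52 percentage points lower from compound 1 to compound 3 (beyond the scatter) and beyond the scatter, so among these three compounds the clear difference lies between hydrogen and either halogen, not between the two halogens. Nothing measured here explains why compound 2 and compound 3 both stand so far from compound 1.

Still open, from the compounds shown here alone, is whether any group at this place other than hydrogen would bring the same fall, or whether a nitrile, an amine or a methyl group would keep the number closer to that of compound 1. Going by these compounds, it is also open whether fluoro or chloro on another carbon of the same ring would give a step of similar size, since all three compounds speak only for this one position.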